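Lactam in place of the tertiary benzamide on the shared core

A few compounds are considered here, and "the series" means these few. Any claim that something is new, unique, unknown or untested is made for them only; others in the source may bear on it.

Three compounds of the series have been run in a physicochemical assay for lipophilicity, using the shake flask method, in phosphate buffer, measured as octanol-water partition, with a stated time of 30 min, at pH 7.4 (on this read-out lower numbers stand for lower lipophilicity and higher numbers for higher lipophilicity), all sharing the core seen in compound 1 `O=C(Nc1ccccc1)c1cnc(NCc2c(F)ccc3c2CCO3)n2cnnc12`. In this assay compound 1 gives 4.1. Compound 2 `CN(c1ncco1)c1cnc(NCc2c(F)ccc3c2CCO3)n2cnnc12` gives 2.1, and compound 3 `CN(C(=O)c1ccccc1)c1cnc(NCc2c(F)ccc3c2CCO3)n2cnnc12` gives 2.4. Compound 3 thus stands second highest of the three: its value sits close to that of compound 2, since a number 0.30 log units higher from compound 2 to compound 3 (within the scatter), while it lies well under compound 1, since a number 1.70 log units lower from compound 1 to compound 3 (beyond the scatter).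

The next compound, compound 4 `C[C@H]1CC(=O)N(c2cnc(NCc3c(F)ccc4c3CCO4)n3cnnc23)C1`, is still to be measured. It differs from compound 3 in one place: 4-methyl-2-oxopyrrolidin-1-yl in place of benzoyl(methyl)amino on an aromatic carbon. For the measured compounds named here, two measured steps bear on this move. The large drop seen as a number 1.70 log units lower from compound 1 to compound 3 (beyond the scatter) shows how far a change at this position on the core can shift the read-out, and the small step of a number 0.30 log units higher from compound 2 to compound 3 (within the scatter) shows that swapping one group for another of similar size at this position can also leave the value where it was. Compound 4 keeps the amide carbonyl of compound 3 but loses the six-membered aromatic ring of carbon only and gains the five-membered non-aromatic ring with 1 hetero atom. A downward step in this assay is therefore expected, with the shift from compound 3 to compound 4 estimated as a number 0.80 log units lower from compound 3 to compound 4 (beyond the scatter). For compound 4 the expected value in this assay is 1.6, with a likely range from 1 to 2.3.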

Compound 4, distribution coefficient: 1.8
The estimate for compound 4 lay 0.20 log units below the measured number, within the range that was stated.
By their numbers in this assay, from the lowest: compounds 4, 2 and 3 (each within the scatter of the next, the first and the last beyond it); then compound 1.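

In this assay, 4-methyl-2-oxopyrrolidin-1-yl puts a substituent with no aromatic ring on this aromatic carbon for the first time among these compounds, and its exchange for benzoyl(methyl)amino gives a number 0.60 log units lower from compound 3 to compound 4 (beyond the scatter), whereas the earlier exchange of substituents between compound 2 and compound 3 stayed within the scatter. Against methyl(1,3-oxazol-2-yl)amino the same ring gives a number 0.30 log units lower from compound 2 to compound 4 (within the scatter), so this read-out separates compound 4 from compound 3 but does not separate it from compound 2. The span seen at this position now reaches a number 2.30 log units lower from compound 1 to compound 4 (beyond the scatter), with phenylcarbamoyl still standing apart from the other three groups.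

No measured evidence bears on the reason for any of these steps. The compounds shown leave open what the methyl group and the defined stereocentre of the ring contribute, and how the unsubstituted 2-oxopyrrolidin-1-yl, the opposite enantiomer, a morpholine or a carboxylic acid on this aromatic carbon would read in this assay.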